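The source may report more compounds than this note shows. Statements on the series, on what has been measured and on what is new or still open speak of the compounds shown alone.

Of the compounds shown here, three share one core and have been tested in an assay on isolated protein for displacement of a labelled ligand from metabotropic glutamate receptor 5 (Homo sapiens), with a stated time of 60 min, tested at 1 uM; on this read-out lower numbers stand for less inhibition and higher numbers for more inhibition at the one concentration tested (going by the name of the read-out). Compound 1 `COc1ccc2ncc(S(=O)(=O)c3ccc(C)c(Cl)c3)c(N3CCC(C)CC3)c2c1` gives 85% in this assay, and compound 3 `COc1ccc2ncc(S(=O)(=O)c3cccc(C#N)c3)c(N3CCC(C)CC3)c2c1` gives 90%; the change between them, a number 5 percentage points higher from compound 1 to compound 3 (within the scatter), stays within the scatter. Compound 2 `Cc1ccc2ncc(S(=O)(=O)c3cccc(C#N)c3)c(N3CCC(C)CC3)c2c1` gives 52% and stands lowest of the three: the step of a number 38 percentage points higher from compound 2 to compound 3 (beyond the scatter) is large and beyond the scatter, and the value of compound 1 also lies well above that of compound 2.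

Compound 4 `Cc1ccc2ncc(S(=O)(=O)c3ccc(C)c(Cl)c3)c(N3CCC(C)CC3)c2c1` is not yet measured. It differs from compound 2 in one place: 3-chloro-4-methylphenyl in place of 3-cyanophenyl on a sulfonyl sulfur. For the measured compounds named here, the measured step that bears on this change is the one from compound 1 to compound 3, which makes the same exchange in the opposite direction and amounts to a number 5 percentage points higher from compound 1 to compound 3 (within the scatter), a shift within the scatter. The change from compound 2 to compound 4 is therefore expected to give no step beyond the scatter, perhaps a slightly lower number, a number 4 percentage points lower from compound 2 to compound 4 (within the scatter). Compound 4 is thus estimated at 48% in this assay, with a range from 30% to 66%.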

Compound 4, a percentage reported as inhibition, at one concentration (the size of the read-out at that concentration, not a potency): 91%
Compound 4: the middle estimate sits 43 percentage points below what was measured; measured number above the stated range.
By their numbers in this assay, from the lowest: compound 2; then compounds 1, 3 and 4 (each within the scatter of the next).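

The exchange on the sulfonyl sulfur turns out to depend on the rest of the molecule: with methyl on the aromatic carbon, 3-chloro-4-methylphenyl in place of 3-cyanophenyl gives a number 39 percentage points higher from compound 2 to compound 4 (beyond the scatter), far from the small step seen with methoxy there: the same change on two cores in this assay, a number 5 percentage points higher (within the scatter) from compound 1 to compound 3 and a number 39 percentage points lower (beyond the scatter) from compound 4 to compound 2, 44 percentage points apart, beyond the scatter of two such steps

Methyl in place of methoxy, with 3-chloro-4-methylphenyl on the sulfonyl sulfur, gives only a number 6 percentage points higher from compound 1 to compound 4 (within the scatter), so the large step seen with 3-cyanophenyl does not carry over: the same change on two cores in this assay, a number 38 percentage points higher (beyond the scatter) from compound 2 to compound 3 and a number 6 percentage points lower (within the scatter) from compound 4 to compound 1, 44 percentage points apart, beyond the scatter of two such steps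

Among these four compounds, only compound 2, which pairs methyl with 3-cyanophenyl, stands apart with a low number in this assay.

The data cannot tell why this one combination falls, and one tested concentration cannot separate compounds 1, 3 and 4, which lie within the scatter of each other. From the compounds shown here alone, it also remains open whether the same dependence holds with an amine in place of the nitrile, or with ethoxy in place of methoxy.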